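Shortening the thioether chain of a chloromethyl ketone

The compounds below may be only part of what the source reports. "The series", "measured", "known", "first", "only" and "open" are said of these compounds alone.

Compound 2 `CC(=O)N[C@@H](CSC/C=C(\C)CC/C=C(\C)CCC=C(C)C)C(=O)CCl` gives 3000 nM in a functional assay on NALM-6 cells (Homo sapiens) (on this read-out lower numbers stand for stronger inhibition and higher numbers for weaker inhibition), the lowest of the two numbers there. Compound 3 `CC(C)=CCC/C(C)=C/CC/C(C)=C/CSC[C@H](NC(=O)OC(C)(C)C)C(=O)CCl` gives 10700 nM in this assay, and that change is a 3.6-fold higher number from compound 2 to compound 3 (0.55 log units; beyond the scatter). For compound 1 `CC(=O)N[C@@H](CSC/C=C(\C)CCC=C(C)C)C(=O)C=[N+]=[N-]` there is only (the limit of > 100000 nM in this assay, at which 1 of the 3 values shown sits), not a number: compound 1 gives > 100000 nM. Compound 4 `CC(=O)N[C@@H](CSC/C=C(\C)CCC=C(C)C)C(=O)CCl` differs from compound 2 by hydrogen in place of 3-methylbut-2-en-1-yl on a saturated chain carbon bound to a double-bonded chain carbon. Among the compounds with values here, no measured step touches this chain: the step of a 3.6-fold higher number from compound 2 to compound 3 (0.55 log units; beyond the scatter) concerns the carbonyl substituent, and compound 1 differs from compound 4 in two places, so its limit cannot be read as a step. The expected change is nonetheless a weakening, estimated as a 5.0-fold higher number from compound 2 to compound 4 (0.70 log units; beyond the scatter). Compound 4 is estimated at 15000 nM, between 4000 nM and 60000 nM.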

Compound 4, half-maximal inhibitory concentration: > 100000 nM
Compound 4 was reported as a limit; the forecaster's own chance of this, stated with the estimate: 25%; at least 6.6-fold (0.82 log units) between middle value and limit.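

In this assay, taking 3-methylbut-2-en-1-yl off the thioether chain gives an at least 33-fold higher number from compound 2 to compound 4 (1.52 log units; beyond the scatter), so this chain carries far more weight than the modest carbonyl change seen earlier. Compound 4 is reported only as a limit, which leaves the true size of this step unknown. The step between compound 1 and compound 4 cannot be read, since both are limits: the limit of > 100000 nM in this assay, at which 2 of the 4 values shown sit.

On these data alone, whether a chain longer than that of compound 2 would lower the number further, or a fully saturated chain of the same length would keep it, remains open.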